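From 5-methylpyridin-2-yl to 2,4-dimethylphenyl: a solubility estimate

A few compounds are considered here, and "the series" means these few. Any claim that something is new, unique, unknown or untested is made for them only; others in the source may bear on it.

Of the compounds shown here, three sharing one core have been measured in a physicochemical assay for solubility, read by HPLC, in phosphate buffer, with a stated time of 16 h, at pH 6.8; on this read-out higher numbers stand for higher solubility and lower numbers for lower solubility. Compound 1 (`Cc1ccc([C@H](C)NC(=O)Cn2nnc3ccccc3c2=O)cc1`) gives 12000 nM, and compound 2 (`COc1ccc([C@H](C)NC(=O)Cn2nnc3ccccc3c2=O)cc1`) gives 15000 nM. Swapping between these two makes little difference, with a 1.3-fold higher number from compound 1 to compound 2 (0.10 log units; within the scatter). Compound 3 (`Cc1ccc([C@H](C)NC(=O)Cn2nnc3ccccc3c2=O)nc1`) gives 2000 nM, the lowest of the three numbers.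

Compound 4 (`Cc1ccc([C@H](C)NC(=O)Cn2nnc3ccccc3c2=O)c(C)c1`) has not yet been measured. It differs from compound 3 in one group, with 2,4-dimethylphenyl in place of 5-methylpyridin-2-yl on a saturated chain carbon bound to an amide-type nitrogen and a saturated chain carbon.

For the measured compounds named here, two measured steps bear on this change, a 6.0-fold lower number from compound 1 to compound 3 (0.78 log units; beyond the scatter) and a 7.5-fold lower number from compound 2 to compound 3 (0.88 log units; beyond the scatter). Both are modest drops on going from a ring of carbon only to 5-methylpyridin-2-yl. Compound 4 makes the reverse kind of change, so a modest rise of similar size is expected in this assay. Going by the values given here, no measured compound carries 2,4-dimethylphenyl itself, so the rise may turn out smaller or larger than those two steps suggest, and the range is kept wide. The estimated move is a 4.5-fold higher number from compound 3 to compound 4 (0.65 log units; beyond the scatter). Compound 4 is expected to give about 9000 nM, with an estimated range from 3000 nM to 22000 nM.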

Compound 4, solubility: 2700 nM
Compound 4: middle estimate off by 3.3-fold (0.52 log units), on the high side; measured number outside the range, below it.
By their numbers in this assay, from the lowest: compounds 3 and 4 (each within the scatter of the next); then compounds 1 and 2 (each within the scatter of the next).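

In this assay, a ring of carbon only at this position does not by itself keep the number high: replacing 5-methylpyridin-2-yl with 2,4-dimethylphenyl gives a 1.4-fold higher number from compound 3 to compound 4 (0.13 log units; within the scatter), so the low number of compound 3 is not unique to the ring holding a nitrogen. The comparison with the other carbon-only rings shows that this position responds to a small change, as one added methyl gives a 4.4-fold lower number from compound 1 to compound 4 (0.65 log units; beyond the scatter), while exchanging 4-methoxyphenyl for 2,4-dimethylphenyl gives a 5.6-fold lower number from compound 2 to compound 4 (0.74 log units; beyond the scatter). No measurement on hand explains why these compounds behave this way.

The compounds shown leave open whether adding a further methyl to 5-methylpyridin-2-yl would lower the number as it does on the ring of compound 1, or leave it unchanged. They also do not show whether chlorine in place of the added methyl would give a similar step, or how this position would respond to a ring carrying an amine or a carboxylic acid, groups that none of these four compounds contains.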